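Swapping the amide tail in a cytotoxicity series

This account rests on a few compounds, and the source may have more. Where it says the series, first, only, none or still open, it means among the compounds named here.

Of the compounds shown here, two sharing one core have been tested so far. Compound 1 `CN1CCN(C[C@H]2CN(c3ccc(-n4cc(-c5ccccn5)cn4)c(F)c3)C(=O)O2)CC1` carries a 4-methylpiperazin-1-yl group on a saturated chain carbon, and in an ADME assay on HEK293-A cells (Homo sapiens) for cytotoxicity, read by MTT assay, with a stated time of 48 h (on this read-out lower numbers stand for stronger inhibition and higher numbers for weaker inhibition), compound 1 gives 70 ug/mL. Compound 2 `CCC(=O)NC[C@H]1CN(c2ccc(-n3cc(-c4ccccn4)cn3)c(F)c2)C(=O)O1` has a propanoylamino group at that place instead, and in this assay compound 2 gives 389 ug/mL. For the measured compounds named here, the only step seen so far, a 5.6-fold higher number from compound 1 to compound 2 (0.74 log units; beyond the scatter), is therefore a shift toward weaker cytotoxicity with a change at the chain carbon. Compound 2 stands at the higher of the two numbers.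

Compound 3 `O=C(NC[C@H]1CN(c2ccc(-n3cc(-c4ccccn4)cn3)c(F)c2)C(=O)O1)C(F)F` keeps the amide but changes its end: difluoromethyl in place of ethyl on a carbonyl carbon. Going by the values given here, no step that has been measured touches this carbonyl carbon, so the one step seen offers no direct guide; it shows only that this end of the molecule can move the number. With nothing more to go on, compound 3 is expected to remain close to compound 2, with a step of a 1.3-fold lower number from compound 2 to compound 3 (0.11 log units; within the scatter) that is not expected to exceed the scatter. The estimate for compound 3 in this assay is 300 ug/mL, within a range from 120 ug/mL to 800 ug/mL.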

Compound 3, half-maximal inhibitory concentration: 167 ug/mL
Compound 3: the middle estimate sits 1.8-fold (0.25 log units) above what was measured; measured number inside the range.
By their numbers in this assay, from the lowest: compound 1; then compound 3; then compound 2.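

In this assay, the far end of the amide turns out to matter by itself: a 2.3-fold lower number from compound 2 to compound 3 (0.37 log units; beyond the scatter), so difluoromethyl in place of ethyl on a carbonyl carbon moves the number beyond the scatter even though the amide stays in place. The earlier step exchanged the whole 4-methylpiperazin-1-yl group, whereas this one leaves the amide-type nitrogen untouched and still shifts the read-out toward stronger inhibition. The amide does keep its lead over the amine-bearing compound, with a 2.4-fold higher number from compound 1 to compound 3 (0.38 log units; beyond the scatter), and no measurement at hand gives a reason for the shift at the carbonyl carbon.

The swap adds fluorine and removes a carbon at the same time, so the compounds shown cannot separate the two changes; a methyl, a fluoromethyl or a trifluoromethyl group on the carbonyl carbon would help to do that. Also open, from the compounds shown here alone, is whether a longer chain such as butanoyl, or a carboxylic acid at this end, would raise or lower the number.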